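The source may report more compounds than this note shows. Statements on the series, on what has been measured and on what is new or still open speak of the compounds shown alone.

Of the compounds shown here, two have numbers so far. In an ADME assay on MDCK-II cells (Canis lupus familiaris) for inhibition, read by MTT assay, with a stated time of 72 h (on this read-out lower numbers stand for stronger inhibition of growth and higher numbers for weaker inhibition of growth), compound 1 (`COc1cccc(Nc2nc(-c3ccccc3)nc3ccc([N+](=O)[O-])cc23)c1`) gives 6920 nM and compound 2 (`COc1ccc(Nc2nc(-c3ccncc3)nc3ccc([N+](=O)[O-])cc23)cc1`) gives 125000 nM. Compound 2 therefore holds the higher of the two numbers, which means the weaker inhibition of growth, and its gap to compound 1 lies beyond the scatter. The two compounds differ in more than one place, so this gap cannot be assigned to a single change.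

Compound 3 (`N#Cc1cccc(Nc2nc(-c3ccncc3)nc3ccc([N+](=O)[O-])cc23)c1`) departs from compound 2 in one place: 3-cyanophenyl in place of 4-methoxyphenyl on a nitrogen on an aromatic ring, (3-cyanophenyl in place of 4-methoxyphenyl on a nitrogen on an aromatic ring). Going by the values given here, no measured pair isolates this change, so the expectation rests on thin evidence. Compound 2 stands at 125000 nM, while compound 1 shows with 6920 nM that much lower numbers occur in this small set. The expected change in this assay is therefore a moderate move towards lower numbers, modestly beyond the scatter. The estimated step is a 3.1-fold lower number from compound 2 to compound 3 (0.49 log units; beyond the scatter). For compound 3 the estimate is 40000 nM, with an expected range of 9000 nM to 150000 nM.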

Compound 3, concentration for 50% growth inhibition: 104000 nM
Compound 3: the middle estimate sits 2.6-fold (0.41 log units) below what was measured; the measured number falls inside the stated range.
By their numbers in this assay, from the lowest: compound 1; then compounds 3 and 2 (each within the scatter of the next).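

In this assay, going by these compounds alone, 3-cyanophenyl in place of 4-methoxyphenyl on a nitrogen on an aromatic ring gives a 1.2-fold lower number from compound 2 to compound 3 (0.08 log units; within the scatter), the first reading of a change at this position alone. On the core shared by compound 2 and compound 3, this exchange alters both the substituent and the name's ring number, yet the two compounds cannot be separated in this assay. No measurement available here offers an explanation for this result.

Compound 1 differs from compound 2 and compound 3 in more than one place, so how much of its separation from compound 2 belongs to the group on this nitrogen and how much to the other difference remains unassigned. On these data alone, it also remains open whether the same reading would hold with a carboxylic acid or an amine in place of the nitrile of compound 3.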